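The source may report more compounds than this note shows. Statements on the series, on what has been measured and on what is new or still open speak of the compounds shown alone.

Among the compounds with values here, compound 2 `Cc1ccc(S(=O)(=O)Oc2ccc3c(CSc4nc5ccc(C)cc5c(=O)[nH]4)cc(=O)oc3c2)cc1` is measured in an ADME assay on Vero cells (Chlorocebus sabaeus) for cytotoxicity, read by polymerase chain reaction, with a stated time of 18 h (a lower number here means that less compound is tolerated, a higher number that more compound is tolerated), at 114000 nM; of the three numbers known, the nearest is that of compound 1 and the furthest that of compound 3, both within the scatter. Compound 1 `Cc1ccc(S(=O)(=O)Oc2ccc3c(CSc4nc5ccccc5c(=O)[nH]4)cc(=O)oc3c2)cc1` gives 117000 nM, and the step of a 1.0-fold lower number from compound 1 to compound 2 (0.01 log units; within the scatter) is within the scatter. Compound 3 `Cc1ccc2nc(SCc3cc(=O)oc4cc(OS(=O)(=O)c5ccc(F)cc5)ccc34)[nH]c(=O)c2c1` gives 86400 nM, and a 1.3-fold lower number from compound 2 to compound 3 (0.12 log units; within the scatter) is likewise within the scatter. Compound 4 `Cc1ccc(S(=O)(=O)Oc2ccc3c(CSC4=NCCC(=O)N4)cc(=O)oc3c2)cc1` differs from compound 2 on the sulfur: a group of 7 heavy atoms (4 carbon, 2 nitrogen, 1 oxygen; one six-membered non-aromatic ring with 2 hetero atoms) in place of a group of 12 heavy atoms (9 carbon, 2 nitrogen, 1 oxygen; one six-membered aromatic ring of carbon only, one six-membered aromatic ring with 2 hetero atoms), on a sulfur. Neither measured step touches the group on the sulfur; both altered only a substituent on an aromatic carbon and stayed within the scatter, so they cannot show how this larger exchange will read. The expectation for compound 4 is therefore a step of a 1.1-fold lower number from compound 2 to compound 4 (0.06 log units; within the scatter), not beyond the scatter. Compound 4 is estimated at 100000 nM, in a range from 40000 nM to 250000 nM.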

Compound 4, half-maximal cytotoxic concentration: 60200 nM
Compound 4: middle estimate off by 1.7-fold (0.22 log units), on the high side; low and high end bracket the measured number.
By their numbers in this assay, from the lowest: compounds 4, 3, 2 and 1 (each within the scatter of the next).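

In this assay, an exchange of the whole group on the sulfur, rather than of a substituent on an aromatic carbon, gives a 1.9-fold lower number from compound 2 to compound 4 (0.28 log units; within the scatter) and also a 1.9-fold lower number from compound 1 to compound 4 (0.29 log units; within the scatter). This position thus tolerates the loss of the six-membered aromatic ring of carbon only, and a smaller non-aromatic ring in its place, without a step beyond the scatter. No measurement shown bears on the reason for these steps. The compounds shown leave open how this assay reads when an open alkyl chain, an amine or a carboxylic acid stands on the sulfur instead of a ring.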